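This account rests on a few compounds, and the source may have more. Where it says the series, first, only, none or still open, it means among the compounds named here.

Compound 1, `O=C(O)c1cnc2c(F)cc(F)cc2c1`, gives 25 mg/kg in a functional assay on the whole organism (strain Sprague-Dawley) for inhibition, with Rattus norvegicus as the target; on this read-out higher numbers stand for an effect only at larger amounts of compound and lower numbers for an effect already at smaller amounts. Compound 2, `Fc1cccc2cc(-c3nn[nH]n3)cnc12`, gives only a limit of this assay, > 10 mg/kg. Compound 3, `FC(F)(F)c1cccc2cc(-c3nn[nH]n3)cnc12`, likewise gives only a limit, < 25 mg/kg.

Compound 2 thus stands at a limit, known only as the limit of > 10 mg/kg in this assay, at which 1 of the 3 values shown sits, and cannot be ranked against compound 1. Compound 4, `Fc1cc(F)c2ncc(-c3nn[nH]n3)cc2c1`, differs from compound 2 by fluoro in place of hydrogen on an aromatic carbon. Among the measured compounds shown here, no measured step bears directly on this change; the single step, a step that the limit leaves unreadable from compound 2 to compound 3, is left unreadable because of the limit of < 25 mg/kg in this assay, at which 1 of the 3 values shown sits, together with the limit of > 10 mg/kg in this assay, at which 1 of the 3 values shown sits. Compound 4 shares both fluoro groups with compound 1, which gives 25 mg/kg. Compound 4 is therefore expected to give 25 mg/kg (range 10 mg/kg to 60 mg/kg), an expected step that the limit leaves unreadable from compound 2 to compound 4 whose direction a limit cannot settle.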

Compound 4, minimum effective dose: 10 mg/kg
The estimate for compound 4 lay 2.5-fold (0.40 log units) above the measured number; low and high end bracket the measured number.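

With both fluoro groups held in place, 2H-tetrazol-5-yl in place of carboxy gives a 2.5-fold lower number from compound 1 to compound 4 (0.40 log units; beyond the scatter) in this assay. Among the compounds shown here, this is the first readable step in the set, and it concerns the group on the core rather than the ring fluoro. Fluoro in place of hydrogen on this aromatic carbon gives a number no higher from compound 2 to compound 4 (the limit leaves the size open) in this assay. The effect of this change still cannot be sized, and the other steps cannot be read either, because they rest on a limit: the limit of > 10 mg/kg in this assay, at which 1 of the 4 values shown sits.

The compounds shown leave open how chloro or methoxy on this aromatic carbon would read. They also leave open whether an amide in place of the 2H-tetrazol-5-yl would move the number.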